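The compounds below may be only part of what the source reports. "The series", "measured", "known", "first", "only" and "open" are said of these compounds alone.

Measured compounds:
- compound 2 `COc1c(C(=O)CCC2CCN(CC3CCCCC3)CC2)cc(Cl)c2[nH]ccc12`: 5.1 nM in an assay on Jurkat cells for displacement of a labelled ligand from Sigma non-opioid intracellular receptor 1 (Homo sapiens), read by scintillation counting, with a stated time of 2 h; on this read-out higher numbers stand for weaker inhibition and lower numbers for stronger inhibition
- compound 3 `COc1c(C(=O)CCC2CCN(Cc3ccccc3)CC2)cc(Cl)c2[nH]ccc12`: in this assay compound 3 gives 5.7 nM
- compound 1 `COc1c(C(=O)CCC2CCN(Cc3ccccc3)CC2)cc(Cl)c2[nH]c([Si](C)(C)C)cc12`: in this assay compound 1 gives "not determined" (no result reported)

Compound 2 holds the lowest of the two numbers reported, but the step of a 1.1-fold higher number from compound 2 to compound 3 (0.05 log units; within the scatter) is within the scatter, so compounds 2 and 3 stand together with no order between them. Compound 1 carries a trimethylsilyl group on the shared core and has no result in this assay.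

Compound 4 `O=C(CCC1CCN(CC2CCCCC2)CC1)c1cc(Cl)c2[nH]ccc2c1` is still to be measured. Its change from compound 2 is hydrogen in place of methoxy on an aromatic carbon. Among the measured compounds shown here, the only measured step, from compound 2 to compound 3, alters the group on the amine nitrogen and leaves the aromatic core untouched, so it does not bear on this change. For the measured compounds named here, no step tests the methoxy, and the expectation rests on the value of compound 2 alone, widened for an unprobed change. For compound 4 the expected step is a 2.4-fold higher number from compound 2 to compound 4 (0.37 log units; beyond the scatter), a mild weakening that may well fall within the scatter. The estimate for compound 4 in this assay is 12 nM, with a range from 3 nM to 50 nM.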

Compound 4, inhibition constant: 5.1 nM
Compound 4: the middle estimate sits 2.4-fold (0.37 log units) above what was measured; measured number inside the range.
By their numbers in this assay, from the lowest: compounds 2, 4 and 3 (each within the scatter of the next).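

In this assay, hydrogen in place of methoxy on the aromatic carbon para to a chloro group gives no change at the digits printed from compound 2 to compound 4 (within the scatter). Among the compounds shown here, this is the first step that reads a change on the shared core rather than on the amine nitrogen, and it shows that the methoxy, with its 2 heavy atoms and 1 hydrogen-bond acceptor, can leave this position with no readable difference, at least with the cyclohexyl group of compound 2 in place. Nothing on hand gives a measured property of either compound that could account for this result.

For the compounds shown here, only this one pair tests the position, so it remains open whether the same holds with the phenyl group of compound 3 on the chain carbon bound to the amine nitrogen. Also open, as far as these compounds go, is how other groups on this aromatic carbon would read, such as a fluoro, a hydroxyl or an ethoxy group, since hydrogen and methoxy are the only two compared here.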